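The source may report more compounds than this note shows. Statements on the series, on what has been measured and on what is new or still open speak of the compounds shown alone.

Compound 1 `CCC(=O)N1CC2CC(C1)N2` and compound 2 `CC(C)C(=O)N1CC2CC(C1)N2` share a core and differ only in the group attached to the carbonyl. In an assay on SH-EP1 cells for agonist activity at Neuronal acetylcholine receptor; alpha4/beta2 (Homo sapiens), read by FLIPR and calcium flux (a higher number here means a larger maximal response, a lower number a smaller maximal response), compound 1 gives 110%, while compound 2 gives 71%. The change a number 39 percentage points lower from compound 1 to compound 2 (beyond the scatter) shows that adding methyl in place of hydrogen on a saturated chain carbon bound to a carbonyl carbon and a saturated chain carbon lowered the maximal response. Compound 2 therefore stands at the lower of the two numbers measured in this assay .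

Compound 3 `O=C(C1CCC1)N1CC2CC(C1)N2` carries the change (cyclobutyl in place of isopropyl on a carbonyl carbon). For the measured compounds named here, the only step available for comparison is the one from compound 1 to compound 2, which was large and downward when the group on the carbonyl carbon grew. A further enlargement of that group is expected to lower the response again, by about a number 16 percentage points lower from compound 2 to compound 3 (beyond the scatter) in this assay . Compound 3 is thus estimated to give 55%, between 30% and 85%.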

Compound 3, largest response reached (Emax), in percent of the reference or control that the assay uses: 99%
Compound 3: the middle estimate sits 44 percentage points below what was measured, outside the stated range (above it).
By their numbers in this assay, from the lowest: compound 2; then compound 3; then compound 1.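

In this assay, cyclobutyl in place of isopropyl on a carbonyl carbon gives a number 28 percentage points higher from compound 2 to compound 3 (beyond the scatter), so the response at this position does not simply fall as the group grows: cyclobutyl has one heavy atom more than isopropyl, plus a ring, yet compound 3 reads higher than compound 2. Cyclobutyl in place of ethyl gives a number 11 percentage points lower from compound 1 to compound 3 (beyond the scatter), so compound 3 still falls short of compound 1, and the three compounds form no steady trend with group size. Nothing available here explains why the ring-bearing group behaves differently from isopropyl.

On these data alone, whether the ring or the extra carbon matters more remains open. Cyclopropyl or cyclopentyl on the same carbonyl carbon, or an open-chain group such as tert-butyl, would help separate the two.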